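Compound 3 and the sulfur substituent swap

The compounds below may be only part of what the source reports. "The series", "measured", "known", "first", "only" and "open" are said of these compounds alone.

Among the compounds with values here, in a functional assay on DU-145 cells (Homo sapiens) for inhibition, read by trypan blue exclusion, with a stated time of 96 h (on this read-out lower numbers stand for stronger inhibition of growth and higher numbers for weaker inhibition of growth), compound 3 (`Cc1ccsc1/C=C(/SCc1ccc(Cl)cc1Cl)C(=O)c1ccc(Cl)cc1`) gives 10000 nM, the lowest of the three numbers so far. Compound 1 (`Cc1ccsc1/C=C(/SCc1ccc(Cl)cc1)C(=O)c1ccc(Cl)cc1`) gives 50000 nM, and compound 2 (`Cc1ccc(S/C(=C/c2cc(Cl)cc(Cl)c2Cl)C(=O)c2ccc(Cl)cc2)cc1`) gives 50000 nM.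

Compound 4 (`Cc1ccc(S/C(=C/c2sccc2C)C(=O)c2ccc(Cl)cc2)cc1`) has 4-methylphenyl in place of 2,4-dichlorobenzyl on a sulfur.

Within the data shown here, only one measured step bears on this change: a 5.0-fold lower number from compound 1 to compound 3 (0.70 log units; beyond the scatter), a modest step with chloro in place of hydrogen on an aromatic carbon. The group entering compound 4 carries no chlorine, so that gain may not survive. Among the measured compounds shown here, no measured step covers the swap itself. Compound 2 also has 4-methylphenyl on sulfur and gives 50000 nM, though it differs elsewhere and is only a loose guide. A modest move to a higher number is therefore expected in this assay. The expected step is a 3.0-fold higher number from compound 3 to compound 4 (0.48 log units; beyond the scatter). Compound 4 is estimated at 30000 nM, with an expected range of 10000 nM to 80000 nM.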

Compound 4, concentration for 50% growth inhibition: 50000 nM
The estimate for compound 4 lay 1.7-fold (0.22 log units) below the measured number, within the range that was stated.
By their numbers in this assay, from the lowest: compound 3; then compounds 1, 2 and 4 (each within the scatter of the next).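

On the sulfur, 4-methylphenyl in place of 2,4-dichlorobenzyl gives a 5.0-fold higher number from compound 3 to compound 4 (0.70 log units; beyond the scatter) in this assay, while 4-methylphenyl in place of 4-chlorobenzyl gives no change at the digits printed from compound 1 to compound 4 (within the scatter). Among the three sulfur substituents carried with 3-methylthiophen-2-yl, only 2,4-dichlorobenzyl stands apart, and 4-methylphenyl and 4-chlorobenzyl cannot be told apart. With 4-methylphenyl on the sulfur, 3-methylthiophen-2-yl in place of 2,3,5-trichlorophenyl on a double-bonded chain carbon bound to a double-bonded chain carbon gives no change at the digits printed from compound 2 to compound 4 (within the scatter), so this swap shows no effect here.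

No evidence at hand accounts for the separation of 2,4-dichlorobenzyl from the other two sulfur substituents. Still open, from the compounds shown here alone, is whether an amine, a carboxylic acid or a longer chain on the sulfur would change the number, and whether 2,4-dichlorobenzyl would keep its lower number alongside 2,3,5-trichlorophenyl.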